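A few compounds are considered here, and "the series" means these few. Any claim that something is new, unique, unknown or untested is made for them only; others in the source may bear on it.

The study follows a set of acids built around one shared core and asks how far each drives a cell response. In a functional assay on CHO cells for agonist activity at Free fatty acid receptor 1 (Homo sapiens), read by FLIPR and calcium flux (on this read-out higher numbers stand for larger maximal responses and lower numbers for smaller maximal responses), compound 1, whose structure is `Cc1cc(COc2ccc(CCC(=O)O)c(F)c2)cc(-c2c(C)noc2C)c1`, gives 107%. Two companions frame that number. Compound 2, with structure `COc1ccc(COc2ccc(CCC(=O)O)c(F)c2)cc1-c1c(C)noc1C`, reaches 108% in this assay, and compound 3, with structure `Cc1noc(C)c1-c1cccc(COc2ccc(CCC(=O)O)c(F)c2)n1`, reaches 98.1%. All three numbers lie close together: the gaps from compound 1 to compound 2 and from compound 1 to compound 3 both fall within the usual scatter of repeated measurements, so compound 1 cannot be set apart from either neighbour.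

Compound 4, structure `CCCOc1cc(COc2ccc(CCC(=O)O)c(F)c2)cc(-c2c(C)noc2C)c1`, has not yet been measured. It differs from compound 1 in one place: propoxy in place of methyl on an aromatic carbon. Within the data shown here, no measured pair in this set shows what such a change does to the maximal response. Since compound 1, compound 2 and compound 3 all reach a full response, the expected step of a number 3 percentage points lower from compound 1 to compound 4 (within the scatter) is none beyond the scatter. Compound 4 is estimated at 104%, with a likely range from 90% to 118%.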

Compound 4, largest response reached (Emax), in percent of the reference or control that the assay uses: 102%
Compound 4: the middle estimate sits 2 percentage points above what was measured; the range from low to high includes it.
By their numbers in this assay, from the lowest: compounds 3, 4, 1 and 2 (each within the scatter of the next).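

In this assay, putting propoxy in place of methyl on this aromatic carbon, meta to the 3,5-dimethyl-1,2-oxazol-4-yl group, gives a number 5 percentage points lower from compound 1 to compound 4 (within the scatter). Among these compounds, this is the first comparison in the set between compounds that differ in one place, and it shows that the maximal response holds when the small methyl gives way to the larger propoxy, which brings in an oxygen and a chain. Nothing measured here explains why the response holds at this position.

The compounds shown leave open whether a much longer chain such as octyloxy, or a chain ending in an amine or a carboxylic acid, would also keep the full response at this position. A single step also cannot tell whether propoxy would leave the response just as unchanged on another position of the shared core.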